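Naphthyl to trifluoromethylphenyl on the sulfonyl of compound 3

The source may report more compounds than this note shows. Statements on the series, on what has been measured and on what is new or still open speak of the compounds shown alone.

Of the compounds shown here, three have been measured in a functional assay on CHO cells for antagonist activity at 5-hydroxytryptamine receptor 6 (Homo sapiens), read by FLIPR; on this read-out higher numbers stand for weaker inhibition and lower numbers for stronger inhibition. Compound 1 `COc1ccc(S(=O)(=O)N2CC(C(=O)N3CC(CN)C3)c3ccccc32)c2ccccc12` gives 79.4 nM; compound 2 `CCN(CC)CCCNC(=O)C1CN(S(=O)(=O)c2ccc(OC)c3ccccc23)c2ccccc21` gives 79.4 nM; compound 3 `CN1CCC(N(C)C(=O)C2CN(S(=O)(=O)c3cccc4ccccc34)c3ccccc32)CC1` gives 31.6 nM, the lowest of the three numbers and beyond the scatter from both others. Among the compounds with values here, the one single-point step recorded, no change at the digits printed from compound 1 to compound 2 (within the scatter), concerns the amide side and does not touch the sulfonyl substituent. Compound 4 `CN1CCC(N(C)C(=O)C2CN(S(=O)(=O)c3ccc(C(F)(F)F)cc3)c3ccccc32)CC1` differs from compound 3 by 4-(trifluoromethyl)phenyl in place of naphthalen-1-yl on a sulfonyl sulfur. Within the data shown here, no measured step bears on this change, so the expectation rests on the absence of evidence and allows a wide range. Compound 4 is expected to give 100 nM, within 25 nM to 400 nM; the estimated step of a 3.2-fold higher number from compound 3 to compound 4 (0.50 log units; beyond the scatter) is towards a higher number.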

Compound 4, inhibition constant: 25.1 nM
Estimate against measurement, compound 4: 4.0-fold (0.60 log units) above, and the stated range covers the measured number.
By their numbers in this assay, from the lowest: compounds 4 and 3 (each within the scatter of the next); then compounds 1 and 2 (each within the scatter of the next).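

On the sulfonyl sulfur, 4-(trifluoromethyl)phenyl in place of naphthalen-1-yl gives a 1.3-fold lower number from compound 3 to compound 4 (0.10 log units; within the scatter) in this assay, so this read-out does not separate the two groups. The earlier compounds shown here held no step at this position; here, with the amide side of compound 3 kept, a single six-membered aromatic ring gives a number within the scatter of the two-ring group. No available evidence accounts for this result.

Going by these compounds, whether this holds with the amide sides of compound 1 and compound 2 stays open. Also open, on these data alone, is what an unsubstituted phenyl or a pyridine ring would give on the sulfonyl sulfur.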